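Swapping a Methylfuran for a Methylthiophene

The source may report more compounds than this note shows. Statements on the series, on what has been measured and on what is new or still open speak of the compounds shown alone.

compound 1 `COc1ccc(OC)c(C(=O)/C=C/c2cccs2)c1` gives 8400 nM
compound 2 `COc1ccc(OC)c(C(=O)/C=C/c2ccc(C)o2)c1` gives 26500 nM

In a functional assay on Hep 3B2 cells (Homo sapiens) for cytotoxicity, read by MTT assay (a higher number here means a weaker inhibitor, a lower number a stronger inhibitor), compound 2 has the higher of the two numbers, which makes it the weaker inhibitor of this pair. Still unmeasured is compound 3 `COc1ccc(OC)c(C(=O)/C=C/c2sccc2C)c1` whose change from compound 2 is 3-methylthiophen-2-yl in place of 5-methylfuran-2-yl on a double-bonded chain carbon bound to a double-bonded chain carbon and nothing else. Going by the values given here, one measured step bears on this: a 3.2-fold higher number from compound 1 to compound 2 (0.50 log units; beyond the scatter) when 5-methylfuran-2-yl replaced thiophen-2-yl. Among the compounds with values here, no measured compound shows what the methyl on 3-methylthiophen-2-yl does on its own. Most of that step is expected to reverse, so a 2.7-fold lower number from compound 2 to compound 3 (0.42 log units; beyond the scatter) is the estimated change in this assay toward a lower number. For compound 3 the estimate is 10000 nM with an expected range from 4000 nM to 25000 nM for repeated measurements.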

Compound 3, half-maximal inhibitory concentration: 16700 nM
Compound 3: the middle estimate sits 1.7-fold (0.22 log units) below what was measured; measured number inside the range.
By their numbers in this assay, from the lowest: compounds 1, 3 and 2 (each within the scatter of the next, the first and the last beyond it).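

In this assay, 3-methylthiophen-2-yl and 5-methylfuran-2-yl cannot be told apart at this place: the data give a 1.6-fold lower number from compound 2 to compound 3 (0.20 log units; within the scatter) for that swap. Adding a methyl in place of hydrogen on an aromatic carbon gives a 2.0-fold higher number from compound 1 to compound 3 (0.30 log units; within the scatter) and so has no effect that can be distinguished from scatter. Compound 3 therefore stays within the scatter of both compound 1 and compound 2, although those two differ beyond it. On these data alone, whether an amine or a longer chain here would shift the number clearly remains open. No available evidence explains these numbers.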